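Polar Aryl Swap on a Shared Nucleoside Core

A few compounds are considered here, and "the series" means these few. Any claim that something is new, unique, unknown or untested is made for them only; others in the source may bear on it.

Measured compounds:
Compound 1, `OC[C@H]1O[C@@H](n2cnc3c(NCc4cccc(Br)c4)ncnc32)[C@H](O)[C@@H]1O`, in a functional assay on K562 cells (Homo sapiens) for antiproliferative activity, with a stated time of 72 h (a higher number here means a weaker inhibitor, a lower number a stronger inhibitor), gives 19700 nM.
Compound 2, `COc1ccccc1CNc1ncnc2c1ncn2[C@@H]1O[C@H](CO)[C@@H](O)[C@H]1O`, gives 89000 nM.
Compound 3, `OC[C@H]1O[C@@H](n2cnc3c(NCc4ccc(F)cc4Cl)ncnc32)[C@H](O)[C@@H]1O`, gives 15600 nM.

Compound 3 carries the lowest number of the three. Its step to compound 1 lies within the scatter, so the two cannot be ordered, while its gap to compound 2 is beyond the scatter: a 5.7-fold lower number from compound 2 to compound 3 (0.76 log units; beyond the scatter). Compound 4, `COc1cccc(CNc2ncnc3c2ncn3[C@@H]2O[C@H](CO)[C@@H](O)[C@H]2O)c1O`, differs from compound 3 by 2-hydroxy-3-methoxyphenyl in place of 2-chloro-4-fluorophenyl on a saturated chain carbon bound to a nitrogen on an aromatic ring. Within the data shown here, two measured steps bear on this change. The first is a 4.5-fold higher number from compound 1 to compound 2 (0.65 log units; beyond the scatter), where 2-methoxyphenyl replaced 3-bromophenyl; the second is a 5.7-fold lower number from compound 2 to compound 3 (0.76 log units; beyond the scatter), where 2-chloro-4-fluorophenyl replaced 2-methoxyphenyl. Both put the 2-methoxyphenyl compound at the higher number. Among the measured compounds shown here, the entering 2-hydroxy-3-methoxyphenyl again carries a methoxy group, and no measured compound carries a hydroxyl on that ring, so the size of the step is uncertain. Compound 4 is therefore expected to show a higher number in this assay, by a 3.8-fold higher number from compound 3 to compound 4 (0.59 log units; beyond the scatter). The estimate for compound 4 is 60000 nM, with a range from 20000 nM to 200000 nM.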

Compound 4, half-maximal inhibitory concentration: 27900 nM
Beside the measured number, compound 4's estimate is 2.2-fold (0.33 log units) above it; the range from low to high includes it.
By their numbers in this assay, from the lowest: compounds 3, 1 and 4 (each within the scatter of the next); then compound 2.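

In this assay the step of a 3.2-fold lower number from compound 2 to compound 4 (0.50 log units; beyond the scatter) separates two rings that both carry a methoxy group, so a methoxy group on the ring does not by itself go with the high number of compound 2. Compound 4 cannot be ordered against the halogen-bearing rings, with a 1.8-fold higher number from compound 3 to compound 4 (0.25 log units; within the scatter) and a 1.4-fold higher number from compound 1 to compound 4 (0.15 log units; within the scatter) leaving the three level. At this place, on a saturated chain carbon bound to a nitrogen on an aromatic ring, a ring bearing hydroxyl and methoxy groups therefore reads alongside the halogen-bearing rings, and among the four compounds only compound 2 stands apart.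

The compounds shown leave open whether a hydroxyl group without the methoxy group, or an amine or a carboxylic acid on this ring, would read the same way. Nothing available explains these differences.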